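The source may report more compounds than this note shows. Statements on the series, on what has been measured and on what is new or still open speak of the compounds shown alone.

Of the compounds shown here, three have been measured in a functional assay on A20 cells (Mus musculus) for inhibition, with stated times of 1 h, 16 h and 24 h; on this read-out lower numbers stand for stronger inhibition and higher numbers for weaker inhibition. Compound 1 `N#CCNC(=O)[C@@H]1CC(F)(F)C[C@H]1C(=O)N1CCOCC1` gives 925 nM in this assay, and compound 2 `N#CCNC(=O)[C@@H]1C[C@@H](S(=O)(=O)CC2CC2)C[C@H]1C(=O)N1CCOCC1` gives 4510 nM. Compound 3 `CC1CCN(C(=O)[C@@H]2C[C@H](S(=O)(=O)c3ccccc3)C[C@H]2C(=O)NC2(C#N)CC2)CC1` gives 2 nM in this assay, the lowest of the three numbers; its gaps to compound 1 and to compound 2 both lie beyond the usual scatter, so compound 3 is the strongest inhibitor among them. Compound 4 `CN(C)C(=O)[C@@H]1C[C@H](S(=O)(=O)c2ccccc2)C[C@H]1C(=O)NC1(C#N)CC1` has not yet been measured. It differs from compound 3 in a single place: dimethylamino in place of 4-methylpiperidin-1-yl on a carbonyl carbon. Among the measured compounds shown here, no measured pair shows this kind of change, so its effect is uncertain. A moderate weakening of inhibition is expected, with a step of a 5.0-fold higher number from compound 3 to compound 4 (0.70 log units; beyond the scatter). Compound 4 is therefore estimated to give about 10 nM in this assay, within a range from 2 nM to 50 nM.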

Compound 4, half-maximal inhibitory concentration: 91 nM
For compound 4 the middle estimate is 9.1-fold (0.96 log units) below the measured one; measured number outside the range, above it.
By their numbers in this assay, from the lowest: compound 3; then compound 4; then compound 1; then compound 2.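

In this assay, dimethylamino in place of 4-methylpiperidin-1-yl on a carbonyl carbon gives a 46-fold higher number from compound 3 to compound 4 (1.66 log units; beyond the scatter), a large weakening of inhibition. This position is therefore sensitive to the group it carries, and in this one pair the larger group with the ring goes with the stronger inhibition. No measurement on hand gives a reason for the size of this step.

From the compounds shown here alone, it remains open whether the ring itself or its methyl group matters more. Piperidin-1-yl without the methyl, or diethylamino, could help separate the two.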